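This account rests on a few compounds, and the source may have more. Where it says the series, first, only, none or still open, it means among the compounds named here.

Measured compounds in a functional assay on NCI-H460 cells (Homo sapiens) for cytotoxicity, read by MTT assay, with a stated time of 72 h; on this read-out lower numbers stand for stronger inhibition and higher numbers for weaker inhibition:
Compound 1 `CCCCCCCCNC1=CC(=O)C=C(C[C@]2(C)[C@@H](C)CC[C@]3(C)C(C)=CCC[C@@H]23)C1=O` gives 38000 nM.
Compound 2 `CNC1=CC(=O)C(C(C)(C)C)=CC1=O` gives 63000 nM.
Compound 3 `CCCCNC1=CC(=O)C(C(C)(C)C)=CC1=O` gives 36000 nM.

Among these three numbers compound 1 stands second highest. Its nearest neighbour is compound 3, whose value sits within the scatter of compound 1, and the furthest is compound 2, whose value also lies within the scatter of compound 1; on this assay the three compounds are not told apart.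

Compound 4 `CC1=CCC[C@H]2[C@](C)(CC3=CC(=O)C=CC3=O)[C@@H](C)CC[C@]12C` differs from compound 1 in one place: hydrogen in place of octylamino on a double-bonded ring carbon. Among the measured compounds shown here, the only measured step that touches the amine substituent is the one from compound 2 to compound 3, a 1.8-fold lower number from compound 2 to compound 3 (0.24 log units; within the scatter), which lengthened the chain on the amine nitrogen and left the number essentially unchanged. For the measured compounds named here, no measured pair removes the amine altogether, so the size of the step from compound 1 to compound 4 in this assay is not anchored by anything measured here. Given that the one change seen at this position stayed within the scatter, the number for compound 4 is expected to stay near that of compound 1, as a step of a 1.3-fold lower number from compound 1 to compound 4 (0.10 log units; within the scatter), with a wide range because the change itself is untested.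

Compound 4 is therefore estimated at 30000 nM, within 8000 nM to 100000 nM.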

Compound 4, half-maximal inhibitory concentration: 84000 nM
Estimate against measurement, compound 4: 2.8-fold (0.45 log units) below; low and high end bracket the measured number.
By their numbers in this assay, from the lowest: compounds 3, 1, 2 and 4 (each within the scatter of the next, the first and the last beyond it).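

In this assay, hydrogen in place of octylamino on the double-bonded ring carbon gives a 2.2-fold higher number from compound 1 to compound 4 (0.34 log units; beyond the scatter) and this modest step lies beyond the scatter. The earlier step on the amine substituent, a 1.8-fold lower number from compound 2 to compound 3 (0.24 log units; within the scatter) on a different core, only lengthened the chain on the nitrogen and stayed within the scatter, whereas this pair removes the whole substituent and moves the number past the scatter, with compound 1, the compound that keeps the octylamino group, on the lower side. No measurement shown here bears on why this happens, so the step stands as an observation on the core of compound 1 alone.

The compounds shown do not separate the part played by the nitrogen from that of the octyl chain, since the pair removes both together. A methoxy group or a hydroxyl on that same ring carbon, or a shorter chain such as butylamino on the core of compound 1, would be needed to tell whether the step follows the amine, the chain or any substituent at all.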